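A few compounds are considered here, and "the series" means these few. Any claim that something is new, unique, unknown or untested is made for them only; others in the source may bear on it.

Compound 1 `CC(C)(C)c1ccc2c(c1)OCCC2NC(=O)Nc1cccc2[nH]ncc12` gives 43 nM in a functional assay for antagonist activity at transient receptor potential cation channel subfamily V member 1 (Homo sapiens), read by calcium flux; on this read-out lower numbers stand for stronger inhibition and higher numbers for weaker inhibition.
Compound 2 `CC(C)(C)c1ccc2c(c1)OCC[C@H]2NC(=O)Nc1cccc2[nH]ncc12` gives 31 nM in this assay.
Compound 3 `O=C(Nc1cccc2[nH]ncc12)NC1CCOc2c1cccc2C(F)(F)F` gives 5 nM in this assay.

Among these three, compound 3 has the lowest number in this assay, and its gap to each of the other two lies beyond the usual scatter, so it is the most potent of the set. Compound 4 `O=C(Nc1cccc2[nH]ncc12)NC1CCOc2c(C3CCCCC3)cccc21` is not yet measured. It differs from compound 3 in one place: cyclohexyl in place of trifluoromethyl on an aromatic carbon.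

Within the data shown here, only one measured step exists, and it is a 1.4-fold lower number from compound 1 to compound 2 (0.14 log units; within the scatter); the two compounds of that pair differ only in the fact that one of compounds 1 and 2 is drawn with a defined configuration and the other without, at the place where they differ, not in any group on the aromatic ring. No measured step therefore bears on the exchange of trifluoromethyl for cyclohexyl, and no direction can be read from the numbers shown. The expected step is a 2.0-fold higher number from compound 3 to compound 4 (0.30 log units; within the scatter), which is an estimate resting on the value of compound 3 alone. Compound 4 is expected to give about 10 nM in this assay, within a range from 2 nM to 60 nM.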

Compound 4, half-maximal inhibitory concentration: 15 nM
Estimate against measurement, compound 4: 1.5-fold (0.18 log units) below, within the range that was stated.
By their numbers in this assay, from the lowest: compound 3; then compound 4; then compounds 2 and 1 (each within the scatter of the next).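

In this assay, among these compounds, the exchange of trifluoromethyl for cyclohexyl on this aromatic carbon gives a 3.0-fold higher number from compound 3 to compound 4 (0.48 log units; beyond the scatter) as the first measured step at this place, and it is a modest one. The number therefore responds to the group at this position, yet the larger, fluorine-free carbon ring is accepted there, with compound 4 still at 15 nM in this assay. Nothing measured among these compounds accounts for the size of this step.

From the compounds shown here alone, a single exchange cannot separate the effect of the ring from that of losing the fluorine atoms, so it remains open how a phenyl ring, a methoxy group or an amine at this place would read. Also open, going by these compounds, is how a defined configuration at the saturated ring carbon would read with either of these two groups.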